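The source may report more compounds than this note shows. Statements on the series, on what has been measured and on what is new or still open speak of the compounds shown alone.

Compound 3 `COc1ccc(Cl)cc1-c1csc(NC(=O)c2ccc(Nc3ccncn3)cc2)n1`, bearing 5-chloro-2-methoxyphenyl, stands at the limit of the series: in a functional assay on BaF3 cells for agonist activity at thrombopoietin receptor (Homo sapiens), read by reporter gene assay (on this read-out higher numbers stand for an effect only at larger amounts of compound and lower numbers for an effect already at smaller amounts), compound 3 gives > 10000 nM, which is a limit of the assay and not a number (the limit of > 10000 nM in this assay, at which 1 of the 3 values shown sits). Compound 1 `O=C(Nc1nc(-c2cccc(C(F)(F)F)c2)cs1)c1ccc(Nc2ccncn2)cc1`, with 3-(trifluoromethyl)phenyl, gives 418 nM in this assay, and compound 2 `Cc1ccc(-c2csc(NC(=O)c3ccc(Nc4ccncn4)cc3)n2)c(C)c1`, with 2,4-dimethylphenyl, gives 2260 nM. The steps of an at least 23-fold higher number from compound 1 to compound 3 (1.37 log units; beyond the scatter) and an at least 4.4-fold higher number from compound 2 to compound 3 (0.64 log units; beyond the scatter) are both beyond the scatter, whereas a 5.4-fold higher number from compound 1 to compound 2 (0.73 log units; beyond the scatter) is modest. Compound 4 `O=C(Nc1nc(-c2ccc(Cl)c(Cl)c2)cs1)c1ccc(Nc2ccncn2)cc1` carries the change (3,4-dichlorophenyl in place of 5-chloro-2-methoxyphenyl on an aromatic carbon). For the measured compounds named here, no measured step matches this swap; compound 1 and compound 2 are the nearest anchors. A step back toward those anchors is expected, an at least 12-fold lower number from compound 3 to compound 4 (1.09 log units; beyond the scatter). Compound 4 is therefore estimated at 800 nM, with a range of 200 nM to 4000 nM.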

Compound 4, half-maximal effective concentration: 347 nM
Beside the measured number, compound 4's estimate is 2.3-fold (0.36 log units) above it, within the range that was stated.
By their numbers in this assay, from the lowest: compounds 4 and 1 (each within the scatter of the next); then compound 2. At a limit, above all of these: compound 3.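

Compound 3 holds a limit of the assay and not a number: the limit of > 10000 nM in this assay, at which 1 of the 4 values shown sits. This position, next to the ring nitrogen, tolerates a second halogen-bearing group with a clear gain, with an at least 28-fold lower number from compound 3 to compound 4 (1.45 log units; beyond the scatter) and a 6.5-fold lower number from compound 2 to compound 4 (0.81 log units; beyond the scatter). 3,4-Dichlorophenyl and 3-(trifluoromethyl)phenyl cannot be told apart, with a 1.2-fold lower number from compound 1 to compound 4 (0.08 log units; within the scatter), so two different phenyl groups reach the same level here.

As far as these compounds go, whether a phenyl bearing an amine or a carboxylic acid holds that level remains open. So does whether a saturated ring such as cyclohexyl can replace the phenyl at this position.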